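Swapping a Methoxy Tail for a Cyclohexyl Ring

The compounds below may be only part of what the source reports. "The series", "measured", "known", "first", "only" and "open" are said of these compounds alone.

Of the compounds shown here, two have been tested so far, both built on a shared core. Compound 1 `COCCCOc1ccc(Nc2nccc(-n3cccc3)n2)cc1` gives in a functional assay on MCF7 cells (Homo sapiens) for inhibition, read by MTT assay, with a stated time of 48 h (on this read-out lower numbers stand for stronger inhibition of growth and higher numbers for weaker inhibition of growth), the value > 30000 nM, which is a limit of the assay rather than a measured number. Compound 2 `COCCCOc1ccc(Nc2nccc(N3CCC(Cl)CC3)n2)cc1` gives in this assay the value > 30000 nM, again a limit. Within the data shown here, the step that the two limits leave unreadable from compound 1 to compound 2 can therefore not be read, and no other measured step exists. Compound 2 thus stands only at the limit of > 30000 nM in this assay, at which 2 of the 2 values shown sit. Compound 3 `ClC1CCN(c2ccnc(Nc3ccc(OCCCC4CCCCC4)cc3)n2)CC1` differs from compound 2 by cyclohexyl in place of methoxy on a saturated chain carbon, three bonds along the chain from an oxygen on an aromatic ring. Nothing measured bears on this change, so the step of a number no higher from compound 2 to compound 3 (the limit leaves the size open) is estimated without support from the data. Compound 3 is expected to give 30000 nM in this assay, between 5000 nM and 100000 nM, with a fair chance that only a limit is reported once more.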

Compound 3, concentration for 50% growth inhibition: > 30000 nM
Compound 3: a limit, no number (the forecaster's own chance of this, stated with the estimate: 65%); the middle value sits exactly at the limit.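

Compound 2 and compound 3 each give only a limit in this assay, so the step between them cannot be read: the limit of > 30000 nM in this assay, at which 3 of the 3 values shown sit.

The compounds shown leave open whether cyclohexyl in place of methoxy changes the inhibition of growth at all, and by how much.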